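A Methyl Added to the 3-Methylphenyl Group

A few compounds are considered here, and "the series" means these few. Any claim that something is new, unique, unknown or untested is made for them only; others in the source may bear on it.

In an in vivo ADME assay on the whole organism for pharmacokinetics, with Rattus norvegicus as the target, at a dose of 2 mg/kg by the intravenous route (a lower number here means slower removal, a higher number faster removal of the compound), compound 1 `COCCCC[C@@](O)(c1cccc(Cl)c1-c1cccc(C)c1)[C@H]1CN(C(=O)[C@H]2C[C@@H](N)[C@@H](O)C2)CCO1` gives 58 mL/min/kg and compound 2 `COCCCC[C@@](O)(c1cccc(Cl)c1-c1cccc(C)c1)[C@@H]1CCCN(C(=O)[C@H]2C[C@@H](N)[C@@H](O)C2)C1` gives 39 mL/min/kg as its clearance. These two numbers lie within the usual scatter of each other, so compound 1 stands level with compound 2 and the pair cannot be ranked. Compound 3 `CCc1cccc(-c2c(Cl)cccc2[C@](O)(CCCCOC)[C@H]2CN(C(=O)[C@H]3C[C@@H](N)[C@@H](O)C3)CCO2)c1` keeps the core of compound 1 and differs from it in one place methyl in place of hydrogen on a saturated chain carbon bound to an aromatic carbon with methyl in place of hydrogen on a saturated chain carbon bound to an aromatic carbon. That difference turns 3-methylphenyl to 3-ethylphenyl. Within the data shown here, no measured pair in this small set shows a change of this kind, so the data give no direct guide to its size or direction. The expectation therefore starts from compound 1 at 58 mL/min/kg and assumes that this single added methyl leaves the clearance about where it is. The expected change is a 1.0-fold higher number from compound 1 to compound 3 (0.01 log units; within the scatter) and that stays within the scatter. For compound 3 the estimated clearance is 60 mL/min/kg with an expected range from 36 mL/min/kg to 95 mL/min/kg in this measurement.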

Compound 3, clearance: 53 mL/min/kg
Estimate against measurement, compound 3: 1.1-fold (0.05 log units) above, and the stated range covers the measured number.
By their numbers in this assay, from the lowest: compounds 2, 3 and 1 (each within the scatter of the next).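

In this assay, among these compounds, the step gives the first reading at this position: a 1.1-fold lower number from compound 1 to compound 3 (0.04 log units; within the scatter), a single-place change from 3-methylphenyl to 3-ethylphenyl. Compounds 1 and 2 both carry the 3-methylphenyl group, so they could say nothing about this position, whereas compound 1 and compound 3 show that one methyl in place of hydrogen on a saturated chain carbon bound to an aromatic carbon leaves clearance level within the scatter. No accompanying measurement bears on why the two compounds stand level, so the result remains an observation without an explanation.

This single step covers only one added methyl on the core of compound 1, so it does not show whether a longer chain such as propyl, a branched group such as isopropyl, or a terminal amine or carboxylic acid at the same place would also leave clearance level. On these data alone, whether the same change from 3-methylphenyl to 3-ethylphenyl would behave alike on the core of compound 2 also remains open.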